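The source may report more compounds than this note shows. Statements on the series, on what has been measured and on what is new or still open speak of the compounds shown alone.

In a functional assay on cells (Homo sapiens) for antiproliferative activity, read by sulforhodamine B assay, with a stated time of 48 h (on this read-out higher numbers stand for weaker inhibition and lower numbers for stronger inhibition), compound 1 (`CCCCCCCCCCCCCCCCNC(=O)[C@@H]1CSC(c2cc(OC)c(OC)c(OC)c2)N1`) gives 1800 nM and compound 2 (`CCCCCCCCCCCCCCCCNC(=O)[C@@H]1CSC(c2ccc(OC)c(OC)c2)N1`) gives 1500 nM. Compound 3 (`CCCCCCCCCCCCNC(=O)[C@@H]1CSC(c2ccc(N)cc2)N1`) gives 2200 nM, within the scatter of both. Compound 4 (`CCCCCCCCCCCCCCCCNC(=O)[C@@H]1CSC(c2ccc(N)cc2)N1`) differs from compound 3 by butyl in place of hydrogen on a saturated chain carbon, ten or more bonds along the chain from an amide-type nitrogen. Among the compounds with values here, the only measured step, a 1.2-fold lower number from compound 1 to compound 2 (0.08 log units; within the scatter), lies within the scatter and concerns a methoxy group on the aromatic ring, so it does not test this chain change directly. Compound 1 and compound 2 carry the longer chain of compound 4 but have different aromatic substitution. No step beyond the scatter is therefore expected, and the estimated step is a 1.4-fold lower number from compound 3 to compound 4 (0.14 log units; within the scatter). Compound 4 is estimated at 1600 nM, with an expected range of 750 nM to 3400 nM.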

Compound 4, half-maximal inhibitory concentration: 2300 nM
Compound 4: the middle estimate sits 1.4-fold (0.16 log units) below what was measured; the measured number falls inside the stated range.
By their numbers in this assay, from the lowest: compounds 2, 1, 3 and 4 (each within the scatter of the next).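

Butyl in place of hydrogen on the saturated chain carbon gives a 1.0-fold higher number from compound 3 to compound 4 (0.02 log units; within the scatter) in this assay and is the first direct reading of this chain change, which stays within the scatter with the 4-aminophenyl group present. With the longer chain held, 4-aminophenyl in place of 3,4-dimethoxyphenyl gives a 1.5-fold higher number from compound 2 to compound 4 (0.19 log units; within the scatter) and in place of 3,4,5-trimethoxyphenyl gives a 1.3-fold higher number from compound 1 to compound 4 (0.11 log units; within the scatter), both also within the scatter. Nothing available bears on why these steps are so small. Still open, from the compounds shown here alone, is whether an octyl chain, or a chain carrying a carboxylic acid, would give a step beyond the scatter.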